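From pentylsulfonyl to (2-carboxyphenyl)sulfonyl

A few compounds are considered here, and "the series" means these few. Any claim that something is new, unique, unknown or untested is made for them only; others in the source may bear on it.

Measured so far:
compound 1 `CCCCCS(=O)(=O)N[C@@H](CNC(=O)c1ccc2c(c1)C(=O)N(CCC1CCNCC1)C2)C(=O)O`: 9 nM
compound 2 `CCCCCC(=O)N[C@@H](CNC(=O)c1ccc2c(c1)C(=O)N(CCC1CCNCC1)C2)C(=O)O`: 13 nM
compound 3 `O=C(O)c1ccc(S(=O)(=O)N[C@@H](CNC(=O)c2ccc3c(c2)C(=O)N(CCC2CCNCC2)C3)C(=O)O)cc1`: 7 nM

In a functional assay for inhibition, with Homo sapiens as the target (on this read-out higher numbers stand for weaker inhibition and lower numbers for stronger inhibition), compound 1 gives 9 nM, the second highest of the three numbers, yet both steps leading away from it stay within the scatter: a 1.4-fold higher number from compound 1 to compound 2 (0.16 log units; within the scatter) and a 1.3-fold lower number from compound 1 to compound 3 (0.11 log units; within the scatter). Compound 4 `O=C(NC[C@H](NS(=O)(=O)c1ccccc1C(=O)O)C(=O)O)c1ccc2c(c1)C(=O)N(CCC1CCNCC1)C2` differs from compound 1 in one place: 2-carboxyphenyl in place of pentyl on a sulfonyl sulfur. For the measured compounds named here, the closest precedent is the step from compound 1 to compound 3, where a 4-carboxyphenyl replaced the same pentyl on the sulfonyl sulfur and the number barely moved (a 1.3-fold lower number from compound 1 to compound 3 (0.11 log units; within the scatter)). Replacing the whole pentylsulfonyl group by pentylcarbonyl also changed little (a 1.4-fold higher number from compound 1 to compound 2 (0.16 log units; within the scatter)). A step beyond the scatter is therefore not expected. Compound 4 is estimated at 9 nM, with a range from 4 nM to 25 nM, which means an expected step of no change at the digits printed from compound 1 to compound 4 (within the scatter).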

Compound 4, half-maximal inhibitory concentration: 15 nM
Compound 4: the middle estimate sits 1.7-fold (0.22 log units) below what was measured; measured number inside the range.
By their numbers in this assay, from the lowest: compounds 3, 1, 2 and 4 (each within the scatter of the next, the first and the last beyond it).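

Swapping 4-carboxyphenyl for 2-carboxyphenyl on the sulfonyl sulfur gives the first step in this series to pass the scatter in this assay (a 2.1-fold higher number from compound 3 to compound 4 (0.33 log units; beyond the scatter)), though only modestly. So the two carboxyphenyl groups are not fully interchangeable at this position, while the 2-carboxyphenyl group stays within the scatter of the open-chain compounds (a 1.7-fold higher number from compound 1 to compound 4 (0.22 log units; within the scatter); a 1.2-fold higher number from compound 2 to compound 4 (0.06 log units; within the scatter)). Nothing measured here explains this difference.

Going by these compounds, a plain phenyl on the sulfonyl sulfur, with no carboxylic acid, remains open. So does a chain longer than pentyl.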